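This account rests on a few compounds, and the source may have more. Where it says the series, first, only, none or still open, it means among the compounds named here.

Of the compounds shown here, two of a shared core have been measured so far. Compound 1 `CC1=C(C(=O)Nc2ccc([N+](=O)[O-])cc2)C(c2ccc(Br)cc2)N=C(SCc2ccccc2Cl)N1` and compound 2 `CC1=C(C(=O)Nc2ccc([N+](=O)[O-])cc2)C(c2cccc([N+](=O)[O-])c2)N=C(SCc2ccccc2)N1` were both tested in a functional assay on the whole organism (artery, strain albino) with Rattus norvegicus as the target, with a stated time of 360 min, at a dose of 10 mg/kg by the oral route; on this read-out higher numbers stand for more inhibition at the one dose given (going by the name of the read-out) and lower numbers for less inhibition. In this assay compound 1 gives 13.9%, while compound 2 gives 32.5%. Compound 2 therefore stands highest of the two numbers, and the nearest value, that of compound 1, lies lower by a gap beyond the usual scatter of repeated measurements. Within the data shown here, the two compounds differ in more than one place, so their values are compared only as two readings and no single step between them is drawn.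

Compound 3 `CC1=C(C(=O)Nc2ccc([N+](=O)[O-])cc2)C(c2cccc([N+](=O)[O-])c2)N=C(SCc2ccccc2Cl)N1` has not yet been measured. It differs from compound 2 in one place: chloro in place of hydrogen on an aromatic carbon. In compound 1 the same 2-chlorobenzyl group sits on the sulfur, and compound 1 gives 13.9% in this assay, but compound 1 also carries a different aryl group, so that reading does not isolate the chloro.

On this basis compound 3 is expected to give a step of a number 5.5 percentage points lower from compound 2 to compound 3 (within the scatter) in this assay, that is, no change beyond the scatter or a modest fall. Compound 3 is estimated at 27% in this assay, within a range from 10% to 45%.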

Compound 3, a percentage reported as inhibition, in the whole organism at one dose (the size of the read-out at that dose, not a potency): 17.5%
Compound 3: middle estimate off by 9.5 percentage points, on the high side, and the stated range covers the measured number.
By their numbers in this assay, from the lowest: compounds 1 and 3 (each within the scatter of the next); then compound 2.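

In this assay, among these compounds, chloro in place of hydrogen on an aromatic carbon, ortho to a large group, gives a number 15 percentage points lower from compound 2 to compound 3 (beyond the scatter) with the 3-nitrophenyl group held the same, so this is the first reading of the change from benzyl to 2-chlorobenzyl on its own, and it goes against inhibition at this position. The second change, 3-nitrophenyl in place of 4-bromophenyl on a saturated ring carbon, gives a number 3.6 percentage points higher from compound 1 to compound 3 (within the scatter) and so does not tell these two aryl groups apart while the (2-chlorobenzyl)sulfanyl group stays in place. Nothing measured here accounts for the loss of inhibition that comes with the chloro.

The compounds shown leave open whether fluoro, methoxy or an amine on the same aromatic carbon would read like chloro or like hydrogen, and whether the chloro step would carry over to a compound with the 4-bromophenyl group. They also leave open what a longer chain between the sulfur and the phenyl ring, or a carboxylic acid on that ring, would do to inhibition in this assay at the one dose given.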